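The source may report more compounds than this note shows. Statements on the series, on what has been measured and on what is new or still open speak of the compounds shown alone.

Measured in an ADME assay on MT4 cells (Homo sapiens) for cytotoxicity, read by MTT assay; on this read-out higher numbers stand for lower toxicity in this test and lower numbers for higher toxicity in this test:
compound 1 `O=C(NCc1ccc(Br)cc1)c1nc(-c2ccc(F)cc2)[nH]c(=O)c1O` gives 47500 nM;
compound 2 `O=C(NCc1ccccc1F)c1nc(-c2ccc(F)cc2)[nH]c(=O)c1O` gives 28500 nM;
compound 3 `Cc1ccc(CNC(=O)c2nc(-c3ccc(F)cc3)[nH]c(=O)c2O)cc1C` gives 33500 nM.

Compound 1 lies nearest to compound 3 and furthest from compound 2; both gaps, a 1.4-fold lower number from compound 1 to compound 3 (0.15 log units; within the scatter) and a 1.7-fold lower number from compound 1 to compound 2 (0.22 log units; within the scatter), are within the scatter, as is a 1.2-fold higher number from compound 2 to compound 3 (0.07 log units; within the scatter), so the three compounds cannot be separated on this read-out.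

Compound 4 `O=C(NCc1ccc(Cl)cc1)c1nc(-c2ccc(F)cc2)[nH]c(=O)c1O` differs from compound 1 by chloro in place of bromo on an aromatic carbon. Going by the values given here, no measured step swaps one halogen for another at this place. Among the compounds with values here, the steps that replace the whole 4-bromophenyl by another aryl ring stay within the scatter, and they are the only guidance at hand. A step no larger than the scatter is therefore expected, in no set direction: a 1.1-fold lower number from compound 1 to compound 4 (0.02 log units; within the scatter). Compound 4 is estimated at 45000 nM, range 20000 nM to 95000 nM.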

Compound 4, half-maximal cytotoxic concentration: 44000 nM
Compound 4: middle estimate off by 1.0-fold (0.01 log units), on the high side, within the range that was stated.
By their numbers in this assay, from the lowest: compounds 2, 3, 4 and 1 (each within the scatter of the next).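

In this assay the direct halogen swap on the aromatic carbon gives a 1.1-fold lower number from compound 1 to compound 4 (0.03 log units; within the scatter), so chloro and bromo cannot be separated at this place. The 4-chlorophenyl group also stays within the scatter of the other aryl rings, with a 1.3-fold higher number from compound 3 to compound 4 (0.12 log units; within the scatter) and a 1.5-fold higher number from compound 2 to compound 4 (0.19 log units; within the scatter), so no replacement shown so far separates these compounds on this read-out. No measured evidence bears on these steps.

Still open, on these data alone, is whether an amine or a carboxylic acid in place of the halogen, or a longer chain on the amide nitrogen, would move the number beyond the scatter.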